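Removal of one acetyl from compound 3: growth inhibition estimate

The source may report more compounds than this note shows. Statements on the series, on what has been measured and on what is new or still open speak of the compounds shown alone.

Measured in a functional assay on HT-29 cells (Homo sapiens) for inhibition, read by MTT assay; a higher number here means a weaker inhibitor of growth, a lower number a stronger inhibitor of growth:
compound 1, `CCCCCCCCCCOc1ccc(-c2coc3cc(OCCCCCCCCCC)cc(O)c3c2=O)cc1`: 11.6 uM
compound 2, `O=c1c(-c2ccc(O)cc2)coc2cc(OC(F)F)cc(O)c12`: 4.56 uM
compound 3, `CC(=O)Oc1ccc(-c2coc3cc(OC(C)=O)cc(O)c3c2=O)cc1`: 19.4 uM

Compound 3 has the highest number of the three. Against compound 1 the gap is within the scatter, so no order between the two can be read. Against compound 2 the gap is beyond the scatter, so compound 3 is the weaker growth inhibitor of that pair.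

Compound 4, `CC(=O)Oc1cc(O)c2c(=O)c(-c3ccc(O)cc3)coc2c1`, has not been measured in this assay. It differs from compound 3 in one place: hydrogen in place of acetyl on an oxygen on an aromatic ring. Compound 4 thereby shares with compound 2 the hydroxy on the pendant aromatic ring, while keeping the acetoxy on the shared core that compound 2 lacks.

Among the measured compounds shown here, no measured pair follows this change, so the step from compound 3 to compound 4 is an estimate only. The expected step of a 1.6-fold lower number from compound 3 to compound 4 (0.21 log units; within the scatter) is towards a lower number, modest, and possibly not beyond the scatter; compound 2 with 4.56 uM marks the far end of what seems plausible. Compound 4 is expected to give about 12 uM in this assay, within a range of 4.5 uM to 32 uM.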

Compound 4, concentration for growth inhibition (reported as GI): 4.21 uM
Beside the measured number, compound 4's estimate is 2.9-fold (0.45 log units) above it, and the stated range ends above it.
By their numbers in this assay, from the lowest: compounds 4 and 2 (each within the scatter of the next); then compounds 1 and 3 (each within the scatter of the next).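

In this assay, among the compounds shown here, going from acetoxy to hydroxy on this oxygen on an aromatic ring gives a 4.6-fold lower number from compound 3 to compound 4 (0.66 log units; beyond the scatter), the first single-place change at this position and one that exceeds the scatter. On an oxygen on an aromatic ring at the other changed place, acetyl in place of difluoromethyl gives a 1.1-fold lower number from compound 2 to compound 4 (0.03 log units; within the scatter), so with the hydroxy present these two groups cannot be told apart in this assay. No measurement shown bears on the reason for either step.

Open, as far as these compounds go, is whether a methyl ether or a carboxylic acid on the first oxygen would read like the hydroxy or like the acetoxy. Also open, from the compounds shown here alone, is whether hydroxy in place of the remaining acetoxy of compound 4 would shift the number further.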